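The source may hold more compounds than are shown below. What is called first, only, known or untested is meant among the compounds shown, and "the series" means these compounds.

Three compounds sharing one core have numbers in a functional assay on MCF7 cells (Homo sapiens) for antiproliferative activity, read by MTT assay, with a stated time of 48 h; on this read-out higher numbers stand for weaker inhibition and lower numbers for stronger inhibition: compound 1 `CC(=O)N1N=C(c2ccc3ccccc3c2)OC1c1ccccc1Br` gives 5.49 ug/mL, compound 2 `CC(=O)N1N=C(c2ccc3ccccc3c2)OC1c1ccc(Br)cc1` gives 5.07 ug/mL, and compound 3 `CC(=O)N1N=C(c2ccc3ccccc3c2)OC1c1cccc(F)c1` gives 1.98 ug/mL. Compound 3 holds the lowest of the three numbers, and the steps leading to it are modest but beyond the scatter: a 2.8-fold lower number from compound 1 to compound 3 (0.44 log units; beyond the scatter) and a 2.6-fold lower number from compound 2 to compound 3 (0.41 log units; beyond the scatter).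

Compound 4 `CC(=O)N1N=C(c2ccc3ccccc3c2)OC1c1ccc(F)cc1` has 4-fluorophenyl in place of 3-fluorophenyl on a saturated ring carbon.

For the measured compounds named here, the closest precedent is the move of bromine between the two bromophenyl compounds, a 1.1-fold lower number from compound 1 to compound 2 (0.03 log units; within the scatter), which lies within the scatter. It is only indirect evidence, as it involves a different halogen and a different starting position. The two steps to compound 3 change both the halogen and its position, so they cannot separate those two changes. Going by the values given here, no pair of fluorophenyl isomers has been measured.

A step within the scatter is therefore the main expectation in this assay, with a slight lean towards a higher number because compound 3 gives 1.98 ug/mL, the lowest so far. The expected change is a 1.3-fold higher number from compound 3 to compound 4 (0.10 log units; within the scatter). For compound 4 the estimated value is 2.5 ug/mL, with an expected range of 1.1 ug/mL to 5.5 ug/mL.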

Compound 4, half-maximal inhibitory concentration: 3.02 ug/mL
Beside the measured number, compound 4's estimate is 1.2-fold (0.08 log units) below it; the measured number falls inside the stated range.
By their numbers in this assay, from the lowest: compounds 3, 4, 2 and 1 (each within the scatter of the next, the first and the last beyond it).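

In this assay, the fluorophenyl pair gives the first direct test of fluorine position on this saturated ring carbon, and a 1.5-fold higher number from compound 3 to compound 4 (0.18 log units; within the scatter) cannot be told apart from repeat variation, as was also the case for the bromine pair. The halogen exchange at one fixed position is now isolated as well: a 1.7-fold lower number from compound 2 to compound 4 (0.23 log units; within the scatter) stays within the scatter, and so does a 1.8-fold lower number from compound 1 to compound 4 (0.26 log units; within the scatter) even though it changes both halogen and position, so compound 4 does not separate from either bromophenyl compound, while compound 3 remains beyond the scatter of both. No measurement is available to explain any of these steps.

The gap between compound 3 and the two bromophenyl compounds still mixes halogen and position, with no bromo counterpart of 3-fluorophenyl among the compounds shown. Also open, on these data alone, is how far an amine, a carboxylic acid or a methoxy group on this phenyl ring would shift the number in this assay and whether any such group would move it beyond the scatter of the four halogenated compounds.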